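Swapping an amide for a urea on the naphthalene sulfonamide core

The compounds below may be only part of what the source reports. "The series", "measured", "known", "first", "only" and "open" are said of these compounds alone.

Of the compounds shown here, two have been measured in an assay on L1.2 cells for binding affinity to C-C chemokine receptor type 8 (Homo sapiens); a lower number here means a stronger inhibitor, a higher number a weaker inhibitor. Compound 1 `CCOC(=O)N1CCC(NS(=O)(=O)c2ccc(C(=O)NC3CCCCC3)c3ccccc23)CC1` gives 9.5 nM, and compound 2 `Cc1ccccc1C(=O)Nc1ccc(S(=O)(=O)NC2CCN(C(=O)CCN)CC2)c2ccccc12` gives 11.3 nM. Compound 1 gives the smaller of the two numbers, but the gap to compound 2 lies within the usual scatter, so the two stand together rather than in an order.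

Compound 3 `CCOC(=O)N1CCC(NS(=O)(=O)c2ccc(NC(=O)N3CCCCC3)c3ccccc23)CC1` is the next step from compound 1. The change is ((piperidin-1-yl)carbonyl)amino in place of cyclohexylcarbamoyl on an aromatic carbon: the carbonyl and the nitrogen trade places, and the ring on the far end becomes a piperidine. For the measured compounds named here, no measured pair shows the effect of such a change, so the size of the step is open. A modest weakening within or just beyond the scatter is expected, because compound 2, which carries a different arrangement at this end of the core, still gives 11.3 nM. The step from compound 1 to compound 3 is estimated at a 1.6-fold higher number from compound 1 to compound 3 (0.20 log units; within the scatter). For compound 3 the expected value is 15 nM, with a range from 5 nM to 50 nM.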

Compound 3, inhibition constant: 126 nM
The estimate for compound 3 lay 8.4-fold (0.92 log units) below the measured number, outside the stated range (above it).
By their numbers in this assay, from the lowest: compounds 1 and 2 (each within the scatter of the next); then compound 3.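

Replacing cyclohexylcarbamoyl with ((piperidin-1-yl)carbonyl)amino on this aromatic carbon of the shared core gives a large step in this assay: a 13-fold higher number from compound 1 to compound 3 (1.12 log units; beyond the scatter). The two groups match in heavy atoms and in hydrogen-bond donors and acceptors, and neither carries a net charge, so matching these counts is not enough to keep the number low at this position. Nothing available accounts for the size of the step.

This change alters two things at once: the carbonyl and the nitrogen trade places, and the far ring gains a nitrogen, so the compounds shown cannot say how much of the step belongs to each. A (cyclohexylcarbamoyl)amino group, which would pair the urea with a far ring of carbon only, would help to separate the two.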